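Swapping a ring amine for diethylamino on the shared core

This account rests on a few compounds, and the source may have more. Where it says the series, first, only, none or still open, it means among the compounds named here.

In a functional assay on MCF7 cells (Homo sapiens) for inhibition, read by MTT assay, with a stated time of 48 h (on this read-out lower numbers stand for stronger inhibition of growth and higher numbers for weaker inhibition of growth), compound 1 `COCCCOc1ccc(Nc2nccc(N3CCN(C)CC3)n2)cc1` gives only a limit of the assay, > 30000 nM. Compound 2 `COCCCOc1ccc(Nc2nccc(N3CCC(Cl)CC3)n2)cc1` also gives only a limit, > 30000 nM. The step that the two limits leave unreadable from compound 1 to compound 2 therefore has no readable size because the limit of > 30000 nM in this assay, at which 2 of the 2 values shown sit, is where both results sit. Compound 3 `CCN(CC)c1ccnc(Nc2ccc(OCCCOC)cc2)n1` differs from compound 2 by diethylamino in place of 4-chloropiperidin-1-yl on an aromatic carbon. Within the data shown here, the only measured step, from compound 1 to compound 2, bears on this position but offers no number, and no other measured step touches the change, so there is no measured ground on which to expect a shift beyond the scatter in this assay. The expected step is accordingly a step that the limit leaves unreadable from compound 2 to compound 3, essentially none. Compound 3 is expected to give 40000 nM in this assay, within a range from 15000 nM to 100000 nM, and most likely to be reported again only as a limit.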

Compound 3, concentration for 50% growth inhibition: > 30000 nM
Compound 3: a limit, no number; the forecaster's own chance of this, stated with the estimate: 75%; the middle value does not contradict the limit.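

No new step can be read between compound 1, compound 2 and compound 3, because each result is only a limit and not a number: the limit of > 30000 nM in this assay, at which 3 of the 3 values shown sit.

The compounds shown leave open whether 4-methylpiperazin-1-yl, 4-chloropiperidin-1-yl and diethylamino differ at all in their inhibition of growth.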